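Moving the ring nitrogen in a pyridyloxy series

A few compounds are considered here, and "the series" means these few. Any claim that something is new, unique, unknown or untested is made for them only; others in the source may bear on it.

Measured compounds:
compound 1 `CC(C)CCn1ccc(-c2ccccc2)c(C#N)c1=O`, 8510 nM
compound 2 `CC(C)CCn1ccc(-c2ccc(Oc3ccccc3)cc2)c(C#N)c1=O`, 42 nM
compound 3 `CC(C)CCn1ccc(-c2ccc(Oc3ccccn3)cc2)c(C#N)c1=O`, 646 nM

In a functional assay on CHO cells for positive allosteric modulation of metabotropic glutamate receptor 2 (Homo sapiens), read by scintillation counting and GTPgammaS binding, with a stated time of 30 min (a higher number here means that more compound is needed for the effect, a lower number that less compound is needed), compound 3 stands second highest of the three numbers, a 13-fold lower number from compound 1 to compound 3 (1.12 log units; beyond the scatter) and a 15-fold higher number from compound 2 to compound 3 (1.19 log units; beyond the scatter). Compound 4 `CC(C)CCn1ccc(-c2ccc(Oc3ccncc3)cc2)c(C#N)c1=O` differs from compound 3 by pyridin-4-yl in place of pyridin-2-yl on an oxygen on an aromatic ring. Among the measured compounds shown here, no measured step covers this change; the only step at the same place, a 15-fold higher number from compound 2 to compound 3 (1.19 log units; beyond the scatter), concerns a different exchange. The data give no basis for a step beyond the scatter in this assay in either direction. Compound 4 is therefore expected to land near compound 3, at about 650 nM, within 150 nM to 3000 nM, which means an expected 1.0-fold higher number from compound 3 to compound 4 (0.00 log units; within the scatter).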

Compound 4, half-maximal effective concentration: 550 nM
Compound 4: the middle estimate sits 1.2-fold (0.07 log units) above what was measured; the range from low to high includes it.
By their numbers in this assay, from the lowest: compound 2; then compounds 4 and 3 (each within the scatter of the next); then compound 1.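

Moving the ring nitrogen from pyridin-2-yl to pyridin-4-yl on the oxygen makes no difference that can be read in this assay (a 1.2-fold lower number from compound 3 to compound 4 (0.07 log units; within the scatter)), so the loss against phenyl does not depend on which of these two pyridines sits there. That loss persists with pyridin-4-yl (a 13-fold higher number from compound 2 to compound 4 (1.12 log units; beyond the scatter)), and so does the gain over hydrogen on the aromatic carbon (a 15-fold lower number from compound 1 to compound 4 (1.19 log units; beyond the scatter)). No measurement shown here explains these steps.

Open, going by these compounds, is how pyridin-3-yl on the same oxygen would compare, and whether a phenyl carrying a methoxy group or a fluorine would stay close to compound 2.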